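Sulfone series: trifluoromethoxy in place of trifluoromethyl

The source may report more compounds than this note shows. Statements on the series, on what has been measured and on what is new or still open speak of the compounds shown alone.

Measured so far in a functional assay on VCaP cells (Homo sapiens) for antiproliferative activity, read by propidium iodide staining, with a stated time of 96 h (a lower number here means a stronger inhibitor, a higher number a weaker inhibitor), are three compounds:
- compound 1 `CC(O)(COc1ccccc1C(F)(F)F)C(=O)Nc1ccc(S(F)(F)(F)(F)F)cc1` gives 3100 nM
- compound 2 `CC(O)(COc1ccc(S(F)(F)(F)(F)F)cc1)C(=O)Nc1cccc(S(F)(F)(F)(F)F)c1` gives 8000 nM
- compound 3 `CC(O)(CS(=O)(=O)c1ccc(C(F)(F)F)cc1)C(=O)Nc1ccc(S(F)(F)(F)(F)F)cc1` gives 27700 nM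

Compound 3 (27700 nM) has the highest number of the three and is the weakest inhibitor, with its gaps to compound 2 and compound 1 both beyond the usual scatter. The next compound, compound 4 `CC(O)(CS(=O)(=O)c1ccc(OC(F)(F)F)cc1)C(=O)Nc1ccc(S(F)(F)(F)(F)F)cc1`, has trifluoromethoxy in place of trifluoromethyl on an aromatic carbon, para to a large group (trifluoromethoxy in place of trifluoromethyl on an aromatic carbon). For the measured compounds named here, no step between measured compounds shows what a change of this kind does. Compound 1 and compound 2 each differ from compound 4 in more than one place, so the expectation rests on compound 3 (27700 nM) alone. In this assay no step beyond the scatter is expected, and the estimate amounts to a small one (a 1.3-fold lower number from compound 3 to compound 4 (0.12 log units; within the scatter)). The estimated value for compound 4 is 21000 nM (expected range 9000 nM to 45000 nM).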

Compound 4, half-maximal inhibitory concentration: 95800 nM
Beside the measured number, compound 4's estimate is 4.6-fold (0.66 log units) below it, and the stated range ends below it.
By their numbers in this assay, from the lowest: compound 1; then compound 2; then compound 3; then compound 4.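

In this assay, this position, on an aromatic carbon para to a large group, responds to the exchange: trifluoromethoxy in place of trifluoromethyl gives a 3.5-fold higher number from compound 3 to compound 4 (0.54 log units; beyond the scatter). For the compounds shown here, this is the first one-place step, and it shows that a close replacement here, which adds an oxygen and a hydrogen-bond acceptor to the group, moves the compound towards weaker inhibition, starting from a sulfone that already had a high number. No measurement available here accounts for the step.

This single pair leaves open whether the position favours trifluoromethyl specifically or would accept a chlorine, a nitrile or a methyl group. It also leaves open whether the same exchange on the trifluoromethyl group of compound 1 would move the number in the same direction.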